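Adding One Group to Compound 1

This account rests on a few compounds, and the source may have more. Where it says the series, first, only, none or still open, it means among the compounds named here.

Compound 1 `N=C(N)c1cccc(OCc2ccccc2)c1`: 156000000 nM
Compound 2 `N=C(N)c1ccc(COc2c(Br)cc(C(=N)N)cc2Br)cc1`: 21500000 nM
Compound 3 `N=C(N)c1ccc(COc2c(I)cc(C(=N)N)cc2I)cc1`: 13800000 nM

In an ADME assay on L6 cells (Rattus norvegicus) for cytotoxicity, read by resazurin assay, with a stated time of 72 h (a lower number here means a stronger inhibitor, a higher number a weaker inhibitor), compound 1 gives 156000000 nM, the highest of the three numbers, and both others lie lower by more than the usual scatter. Compound 4 `N=C(N)c1cccc(COc2cccc(C(=N)N)c2)c1` has not yet been measured. It differs from compound 1 by a group of 3 heavy atoms (1 carbon, 2 nitrogen; no ring) in place of a hydrogen atom, on an aromatic carbon, on an aromatic carbon of a six-membered aromatic ring of carbon only, meta to a large group. For the measured compounds named here, no step between measured compounds isolates such a change, so the expectation is loose. It leans on compound 2 at 21500000 nM and compound 3 at 13800000 nM, and a moderate move to a lower number, beyond the scatter, is expected. The expected change is a 3.1-fold lower number from compound 1 to compound 4 (0.49 log units; beyond the scatter). For compound 4 the estimated value is 50000000 nM, with an expected range from 15000000 nM to 130000000 nM.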

Compound 4, half-maximal inhibitory concentration: 24000000 nM
Estimate against measurement, compound 4: 2.1-fold (0.32 log units) above, and the stated range covers the measured number.
By their numbers in this assay, from the lowest: compounds 3, 2 and 4 (each within the scatter of the next); then compound 1.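

In this assay, for the compounds shown here, this is the first step that isolates a single change: a group of 3 heavy atoms (1 carbon, 2 nitrogen; no ring) in place of a hydrogen atom, on an aromatic carbon, meta to a large group, gives a 6.5-fold lower number from compound 1 to compound 4 (0.81 log units; beyond the scatter). This shows that the change at this position alone moves the number beyond the scatter. Nothing measured here accounts for the step.

Going by these compounds, it remains open whether a different group at this position, such as an amine, a nitrile or a carboxylic acid, would give a step of similar size. A single step also cannot show whether the same group would have a similar effect at another place on the ring.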